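A few compounds are considered here, and "the series" means these few. Any claim that something is new, unique, unknown or untested is made for them only; others in the source may bear on it.

Measured in an ADME assay on L02 cells (Homo sapiens) for cytotoxicity, read by MTT assay, with a stated time of 24 h; on this read-out higher numbers stand for weaker inhibition and lower numbers for stronger inhibition:
- compound 1 `O=C1/C(=C/c2cccnc2)CNC/C1=C\c1ccccc1F`: 15900 nM
- compound 2 `O=C1/C(=C/c2cccnc2)CN(S(=O)(=O)c2ccc(C(F)(F)F)cc2)C/C1=C\c1ccccc1F`: 11300 nM

Only these two numbers are available so far. Compound 2 at 11300 nM lies within the scatter of compound 1, so the two cannot be told apart on this read-out.

The next compound to be tested is compound 3 `N#Cc1ccc(S(=O)(=O)N2C/C(=C\c3cccnc3)C(=O)/C(=C/c3ccccc3F)C2)cc1`. It keeps the whole of compound 2 apart from one group: cyano in place of trifluoromethyl on an aromatic carbon. Put another way, 4-(trifluoromethyl)phenyl becomes 4-cyanophenyl.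

Among the compounds with values here, no measured pair differs in one place, so no direct step is available to size this change. Within the data shown here, the only guide is that compound 1 at 15900 nM and compound 2 at 11300 nM sit close together despite their differing structures. No direction is therefore expected, and the expected step of a 1.2-fold higher number from compound 2 to compound 3 (0.06 log units; within the scatter) in this assay stays within the scatter. For compound 3 the estimated value is 13000 nM, with an expected range of 6500 nM to 26000 nM.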

Compound 3, half-maximal inhibitory concentration: > 20000 nM
Compound 3: no number, only a limit; the forecaster's own chance of this, stated with the estimate: 5%; at least 1.5-fold (0.18 log units) between middle value and limit.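

For compound 3 the reading in this assay is a limit and not a number: the limit of > 20000 nM in this assay, at which 1 of the 3 values shown sits. Within the data shown here, at this position, para to a large group, the change from 4-(trifluoromethyl)phenyl to 4-cyanophenyl gives the first one-place step on the sulfonyl aryl group, an at least 1.7-fold higher number from compound 2 to compound 3 (0.24 log units; that floor lies within the scatter), and it fixes a direction only, since the true size is hidden by the limit. Placing (4-cyanophenyl)sulfonyl in place of hydrogen on the amine nitrogen in the ring gives an at least 1.2-fold higher number from compound 1 to compound 3 (0.09 log units; that floor lies within the scatter), so on this read-out neither change to cyano-bearing compound 3 moves the number downward, although neither floor clears the scatter.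

Still open, from the compounds shown here alone, is how far compound 3 lies past its limit, and with it whether cyano and trifluoromethyl truly differ at this position. Also open, going by these compounds, is how a methoxy group or a carboxylic acid on the same aromatic carbon would read in this assay, and whether such a group would fall on the side of compound 2 or on the side of compound 3.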